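Trading 4-hydroxyphenyl for 3-fluorophenyl on compound 2

This account rests on a few compounds, and the source may have more. Where it says the series, first, only, none or still open, it means among the compounds named here.

Within the data shown here, in an ADME assay on the whole organism (Mus musculus, strain Swiss Webster) for pharmacokinetics, read by LC-MS, at a dose of 50 mg/kg by the oral route (a higher number here means more compound in the circulation at the dose given, a lower number less compound in the circulation), compound 2 `O=C(Nc1ccc(F)c(-c2nc3ncc(-c4ccc(O)cc4)cc3[nH]2)c1)N1CCCC1` gives 130 nM, the lower of the two numbers measured so far. Compound 1 `O=C(Nc1ccc(F)c(-c2nc3ncc(-c4ccc(F)c(F)c4)cc3[nH]2)c1)N1CCCC1` gives 6670 nM. Among the measured compounds shown here, putting 4-hydroxyphenyl in place of 3,4-difluorophenyl on an aromatic carbon is the only measured step, a 51-fold lower number from compound 1 to compound 2 (1.71 log units; beyond the scatter), and it is large and beyond the scatter.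

Compound 3 `O=C(Nc1ccc(F)c(-c2nc3ncc(-c4cccc(F)c4)cc3[nH]2)c1)N1CCCC1` has not yet been measured. It changes the same aromatic carbon of compound 2, with 3-fluorophenyl in place of 4-hydroxyphenyl on an aromatic carbon. For the measured compounds named here, the entering group is not the one carried by compound 1, and no measurement isolates 3-fluorophenyl, so the single step is only an approximate guide. Even so, like compound 1 at 6670 nM, compound 3 carries a fluorinated phenyl group rather than 4-hydroxyphenyl, so a large move towards a higher number is expected, perhaps somewhat short of the full measured distance. The expected change is a 27-fold higher number from compound 2 to compound 3 (1.43 log units; beyond the scatter), which would lie beyond the scatter. Compound 3 is estimated at 3500 nM, with an expected range of 1000 nM to 10000 nM.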

Compound 3, maximal plasma concentration: 7000 nM
Compound 3: middle estimate off by 2.0-fold (0.30 log units), on the low side, within the range that was stated.
By their numbers in this assay, from the lowest: compound 2; then compounds 1 and 3 (each within the scatter of the next).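

In this assay, the new step, a 54-fold higher number from compound 2 to compound 3 (1.73 log units; beyond the scatter), shows that the large gap at this aromatic carbon does not depend on the 3,4-difluorophenyl group alone, as a ring carrying a single fluorine in the 3-position gives a large step from 4-hydroxyphenyl too. The second fluorine makes no readable difference here: hydrogen in place of fluoro gives a 1.0-fold higher number from compound 1 to compound 3 (0.02 log units; within the scatter), which lies within the scatter, so among these three compounds only compound 2, the one with 4-hydroxyphenyl, stands apart. Nothing measured here accounts for that gap, and the number alone does not tell how it arises.

As far as these compounds go, what remains open is whether the low number belongs to the hydroxyl group itself or to its place on the ring, a question that 3-hydroxyphenyl or 4-methoxyphenyl at this carbon would bear on. Plain phenyl, a 4-fluorophenyl group and an amine on the ring are also absent from the compounds shown, so how far the fluorinated rings' shared level extends to other groups cannot be said.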